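The source may hold more compounds than are shown below. What is called first, only, known or untested is meant among the compounds shown, and "the series" means these compounds.

Compound 1 `COc1ccc(-c2cc3ccc(OC)cc3nc2Nc2ccc(NC(=O)CN(C)C)cc2)cc1`: 9200 nM in a functional assay on HUVEC cells (Homo sapiens) for antiproliferative activity, read by MTT assay, with a stated time of 48 h; on this read-out higher numbers stand for weaker inhibition and lower numbers for stronger inhibition
Compound 2 `CCN(CC)CC(=O)Nc1ccc(Nc2nc3ccc(OC)cc3cc2-c2ccc(OC)cc2)cc1`: 45600 nM in this assay

Compound 2 gives the highest of the two numbers in this assay; compound 1 sits a step below it, beyond the scatter. Compound 3 `COc1ccc(-c2cc3cc(OC)ccc3nc2Nc2ccc(NC(=O)CN3CCCCC3)cc2)cc1` differs from compound 2 by piperidin-1-yl in place of diethylamino on a saturated chain carbon bound to a carbonyl carbon. Among the measured compounds shown here, no measured pair shows this change, so the direction is uncertain; compound 1 and compound 2 only show that the amine on this chain matters. The estimated step from compound 2 to compound 3 in this assay is a 2.1-fold lower number from compound 2 to compound 3 (0.32 log units; beyond the scatter), toward weaker numbers. Compound 3 is expected to give 22000 nM (range 7000 nM to 65000 nM).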

Compound 3, half-maximal inhibitory concentration: > 50000 nM
Compound 3 gave a limit, no number (the forecaster's own chance of this, stated with the estimate: 15%); middle value at least 2.2-fold (0.35 log units) from the limit.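

Among the compounds shown here, compound 3 gave a limit of the assay rather than a number: the limit of > 50000 nM in this assay, at which 1 of the 3 values shown sits. This is the first measured pair at this position, and the step reads an at least 1.0-fold higher number from compound 2 to compound 3 (0.04 log units; that floor lies within the scatter). Piperidin-1-yl in place of diethylamino on this chain carbon thus gives no sign of stronger inhibition in this assay, but the true size of the step cannot be read.

The compounds shown leave open whether another ring amine on this chain, such as morpholin-4-yl or pyrrolidin-1-yl, would give a measurable number on the core of compound 2.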